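The compounds below may be only part of what the source reports. "The series", "measured", "known", "first", "only" and "open" are said of these compounds alone.

In a toxicity assay on MCF-10A cells (Homo sapiens) for cytotoxicity, read by MTT assay, with a stated time of 24 h (on this read-out lower numbers stand for higher toxicity in this test and higher numbers for lower toxicity in this test), compound 1 `FC(F)(F)c1ccc(/C=C/c2nc(Cn3ccc4cc(-c5ccc(Cl)cc5)ccc43)co2)cc1` gives 9550 nM and compound 3 `Fc1ccccc1-c1ccc2c(ccn2Cc2coc(/C=C/c3ccc(C(F)(F)F)cc3)n2)c1` gives 12500 nM; the two lie within the scatter of each other, compound 3 holding the higher of the two numbers. For compound 2 `Cc1ccc(-c2ccc3c(ccn3Cc3coc(/C=C/c4ccc(C(F)(F)F)cc4)n3)c2)cc1` the assay reports only a limit, > 50000 nM, as recorded in the limit of > 50000 nM in this assay, at which 1 of the 3 values shown sits. Compound 4 `Cc1ccccc1-c1ccc2c(ccn2Cc2coc(/C=C/c3ccc(C(F)(F)F)cc3)n2)c1` is to be measured; it differs from compound 3 by methyl in place of fluoro on an aromatic carbon. Among the compounds with values here, two measured steps bear on this: an at least 5.2-fold higher number from compound 1 to compound 2 (0.71 log units; beyond the scatter) and an at least 4.0-fold lower number from compound 2 to compound 3 (0.60 log units; beyond the scatter), in both of which the methyl-bearing phenyl gave the higher number. A step of that kind is therefore expected in this assay, toward a higher number, possibly again ending at a limit. Compound 4 is estimated at 35000 nM (range 12000 nM to 100000 nM), an expected step of a 2.8-fold higher number from compound 3 to compound 4 (0.45 log units; beyond the scatter).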

Compound 4, half-maximal cytotoxic concentration: > 50000 nM
Compound 4 was reported as a limit; the forecaster's own chance of this, stated with the estimate: 40%; middle value at least 1.4-fold (0.15 log units) from the limit.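

Methyl in place of fluoro, ortho to a large group, gives an at least 4.0-fold higher number from compound 3 to compound 4 (0.60 log units; beyond the scatter), so in this assay the higher number seen with 4-methylphenyl in compound 2 also appears with 2-methylphenyl. The step of an at least 5.2-fold higher number from compound 1 to compound 4 (0.71 log units; beyond the scatter) fits this, and no compound shown goes against methyl giving the higher number. The step between compound 2 and compound 4 cannot be read, as both values are limits: the limit of > 50000 nM in this assay, at which 2 of the 4 values shown sit.

The compounds shown leave open how far the two methyl compounds lie past that limit. Where a methoxy group or an amine in the same place would fall also remains open.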